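This account rests on a few compounds, and the source may have more. Where it says the series, first, only, none or still open, it means among the compounds named here.

Compound 2 `N#Cc1cnc(NCc2cnccc2C(F)(F)F)cc1N[C@H]1CC[C@@H](C(N)=O)CC1` carries a 4-carbamoylcyclohexyl on the amine nitrogen of the shared core. In an assay on isolated protein for inhibition of protein kinase C delta type (Homo sapiens), read by TR-FRET, with a stated time of 2 h (a higher number here means a weaker inhibitor, a lower number a stronger inhibitor), compound 2 gives 400 nM, the lower of the two numbers obtained so far. Among the compounds with values here, its only measured neighbour, compound 1 `N#Cc1cnc(NCc2cnccc2C(F)(F)F)cc1N[C@H]1CC[C@@H](O)CC1`, has a hydroxy in place of the carbamoyl on the saturated ring carbon, and in this assay compound 1 gives 4500 nM. Within the data shown here, the single measured step in the set is an 11-fold lower number from compound 1 to compound 2 (1.05 log units; beyond the scatter). Compound 3 `CC1(C)C[C@H](Nc2cc(NCc3cnccc3C(F)(F)F)ncc2C#N)CC[C@@H]1O` differs from compound 2 by 4-hydroxy-3,3-dimethylcyclohexyl in place of 4-carbamoylcyclohexyl on a nitrogen on an aromatic ring. The measured step from compound 1 to compound 2 bears on this change directly, though in reverse: the hydroxy group returns, and on that evidence the number for compound 3 is expected to rise back toward that of compound 1. Among the measured compounds shown here, the two methyl groups added to the ring have no measured counterpart here, so their contribution is unknown and the range around the estimate is kept wide. Compound 3 is therefore expected to show a 6.3-fold higher number from compound 2 to compound 3 (0.80 log units; beyond the scatter), with an estimated value in this assay of 2500 nM, between 600 nM and 9000 nM.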

Compound 3, half-maximal inhibitory concentration: 500 nM
For compound 3 the middle estimate is 5.0-fold (0.70 log units) above the measured one; measured number outside the range, below it.
By their numbers in this assay, from the lowest: compounds 2 and 3 (each within the scatter of the next); then compound 1.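

In this assay, a hydroxy group on the cyclohexyl ring no longer goes only with the high number of compound 1: adding the two methyl groups of the 4-hydroxy-3,3-dimethylcyclohexyl gives a 9.0-fold lower number from compound 1 to compound 3 (0.95 log units; beyond the scatter) on the same nitrogen on an aromatic ring. Set against the carbamoyl, the same group gives a 1.3-fold higher number from compound 2 to compound 3 (0.10 log units; within the scatter), so in this set the 4-carbamoylcyclohexyl and the 4-hydroxy-3,3-dimethylcyclohexyl cannot be told apart, and the carbamoyl is not the only group on this ring that reaches this range. No evidence is at hand on what lies behind either step.

The compounds shown leave open whether a single methyl group on the ring would serve as the pair does, and what the other stereoisomers of the 4-hydroxy-3,3-dimethylcyclohexyl would give. As far as these compounds go, it also remains open whether the two methyl groups would change the number of the 4-carbamoylcyclohexyl in the same way, and whether an amine or a carboxylic acid in place of the hydroxy or the carbamoyl on that saturated ring carbon would fall in the same range.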